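The source may hold more compounds than are shown below. What is called first, only, known or untested is meant among the compounds shown, and "the series" means these compounds.

Compound 1 `CC[C@@H](NC1=NS(=O)(=O)N=C1Nc1cccc(C(=O)N(C)C)c1O)c1ccccc1` gives 8990 nM in an assay on isolated protein for binding affinity to C-X-C chemokine receptor type 1 (Homo sapiens) (a lower number here means a stronger inhibitor, a higher number a weaker inhibitor), and compound 2 `CC[C@@H](NC1=NS(=O)(=O)N=C1Nc1cccc(C(=O)N(C)C)c1O)c1ccc(C)o1` gives 5950 nM. The step of a 1.5-fold lower number from compound 1 to compound 2 (0.18 log units; within the scatter) stays within the scatter. Within the data shown here, compound 3 `CN(C)C(=O)c1cccc(Nc2n[s+]([O-])nc2N[C@@H](c2ccco2)C2(C)CC2)c1O` carries a different core from the one shared by compounds 1 and 2. In this assay compound 3 gives 375 nM, the lowest number of the three; the gaps to compound 2 and to compound 1 both lie beyond the scatter.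

Compound 4 `C[C@H](Nc1n[s+]([O-])nc1Nc1cccc(C(=O)N(C)C)c1O)C(C)(C)C` differs from compound 3 by 1,2,2-trimethylpropyl in place of (furan-2-yl)(1-methylcyclopropyl)methyl on a nitrogen on an aromatic ring. Among the measured compounds shown here, only one measured step touches this region: a 1.5-fold lower number from compound 1 to compound 2 (0.18 log units; within the scatter), an exchange of one aromatic ring for another on that carbon, which left the number within the scatter. For the measured compounds named here, no measured step removes the aromatic ring altogether or alters the 1-methylcyclopropyl, and the two compounds that lack that group sit on another core, so they do not speak directly to the change. The low number of compound 3 was reached with the larger group, while compounds 1 and 2, with simpler substituents on the same nitrogen, sit far higher. Compound 4 is therefore expected to give a higher number, estimated at 1500 nM in this assay, within 400 nM to 6000 nM. The expected step is a 4.0-fold higher number from compound 3 to compound 4 (0.60 log units; beyond the scatter).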

Compound 4, inhibition constant: 484 nM
Compound 4: the middle estimate sits 3.1-fold (0.49 log units) above what was measured, within the range that was stated.
By their numbers in this assay, from the lowest: compounds 3 and 4 (each within the scatter of the next); then compounds 2 and 1 (each within the scatter of the next).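

In this assay the exchange on a nitrogen on an aromatic ring stays within the scatter (a 1.3-fold higher number from compound 3 to compound 4 (0.11 log units; within the scatter)), so on this core (furan-2-yl)(1-methylcyclopropyl)methyl and 1,2,2-trimethylpropyl cannot be told apart. Among these compounds, the only earlier step in this region swapped one aromatic ring for another on a different core, whereas this one removes both the three-membered ring and the five-membered aromatic ring, and with them the single hydrogen-bond acceptor of the group, and takes the group from 10 heavy atoms to 6 without a change beyond the scatter. Nothing measured here explains why the two groups give numbers this close.

Going by these compounds, it remains open how the core of compound 3 compares with the core of compound 1 when the group on that nitrogen is held the same. On these data alone, it is also open how this core would respond if that nitrogen carried a group with a basic amine, a carboxylic acid or a longer unbranched alkyl chain.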